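Swapping a Cyclohexyloxy Group for an Aminopiperidine

A few compounds are considered here, and "the series" means these few. Any claim that something is new, unique, unknown or untested is made for them only; others in the source may bear on it.

Three compounds sharing one core have been measured in a functional assay for inhibition of sodium/hydrogen exchanger (Oryctolagus cuniculus); a higher number here means a weaker inhibitor, a lower number a stronger inhibitor:

Compound 1 `CCC(C)c1cc(C)c(C(=O)N=C(N)N)cc1S(C)(=O)=O` gives 8 nM.
Compound 2 `Cc1cc(O)c(S(C)(=O)=O)cc1C(=O)N=C(N)N` gives 220 nM.
Compound 3 `Cc1cc(OC2CCCCC2)c(S(C)(=O)=O)cc1C(=O)N=C(N)N` gives 37 nM.

Compound 3 stands second highest of these three numbers. Toward the strongest of the set, a 4.6-fold higher number from compound 1 to compound 3 (0.67 log units; beyond the scatter); toward the weakest, a 5.9-fold lower number from compound 2 to compound 3 (0.77 log units; beyond the scatter). The fourth compound, compound 4 `Cc1cc(N2CCC(N)CC2)c(S(C)(=O)=O)cc1C(=O)N=C(N)N`, has not yet been measured. It differs from compound 3 in one place: 4-aminopiperidin-1-yl in place of cyclohexyloxy on an aromatic carbon.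

Within the data shown here, two measured steps bear on this change. The step of a 28-fold higher number from compound 1 to compound 2 (1.44 log units; beyond the scatter) shows that stripping the position down to a small hydroxy group costs a great deal, and the step of a 5.9-fold lower number from compound 2 to compound 3 (0.77 log units; beyond the scatter) shows that filling the same position with a six-membered ring wins part of that back. Compound 4 keeps a six-membered ring of similar size at this position, so the large loss seen for compound 2 is not expected. Among the measured compounds shown here, no measured step, however, covers exchanging the ring oxygen link for a nitrogen link or adding an amino group, so the outcome is uncertain. The estimate for compound 4 in this assay is 80 nM, with a range of 20 nM to 300 nM. This estimate means a step of a 2.2-fold higher number from compound 3 to compound 4 (0.33 log units; beyond the scatter), expected to be modest and toward a higher number.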

Compound 4, half-maximal inhibitory concentration: 9.8 nM
Estimate against measurement, compound 4: 8.2-fold (0.91 log units) above; measured number below the stated range.
By their numbers in this assay, from the lowest: compounds 1 and 4 (each within the scatter of the next); then compound 3; then compound 2.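

In this assay, among these compounds, 4-aminopiperidin-1-yl in place of cyclohexyloxy gives a 3.8-fold lower number from compound 3 to compound 4 (0.58 log units; beyond the scatter), so at this position a ring of the same heavy-atom count can take on nitrogen and a hydrogen-bond donor and still improve the number, something no earlier compound had tested. Measured from the hydroxy compound, the same ring gives a 22-fold lower number from compound 2 to compound 4 (1.35 log units; beyond the scatter), a bigger recovery than cyclohexyloxy achieved, and a 1.2-fold higher number from compound 1 to compound 4 (0.09 log units; within the scatter) places it level with the sec-butyl compound, so a ring-bearing group at this position now matches the small branched chain that cyclohexyloxy had not matched. Nothing available here explains why the amine-bearing ring does better than the ether-linked one.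

These compounds do not separate the two differences between the groups, the ring nitrogen attached to the aromatic carbon and the amino group on the far side of the ring. A plain piperidin-1-yl group would address the first, while a 4-hydroxypiperidin-1-yl group, with a hydroxy in place of the amine, would show whether the amine itself is needed.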